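A few compounds are considered here, and "the series" means these few. Any claim that something is new, unique, unknown or untested is made for them only; others in the source may bear on it.

Three compounds sharing one core were tested in a functional assay on MDA-MB-231 cells (Homo sapiens) for cytotoxicity, read by MTT assay, with a stated time of 48 h; a higher number here means a weaker inhibitor, a lower number a stronger inhibitor. Compound 1 `CCCCCCCCCNC(=O)N(Cc1cc(OC)ccc1OC)n1cnnc1`, which carries an alkyl chain on the urea, gave in this assay only a limit, > 50000 nM. Compound 2 `COc1cc(CN(C(=O)Nc2ccc(C)cc2)n2cnnc2)cc(OC)c1OC`, whose benzyl ring carries methoxy groups, likewise gave only a limit in this assay, > 50000 nM. Compound 3 `N#Cc1ccc(CN(C(=O)Nc2cc(C(F)(F)F)cc(C(F)(F)F)c2)n2cnnc2)cc1`, with a nitrile on the benzyl ring and trifluoromethyl groups on the aryl urea, gave a number in this assay, 9280 nM. Compound 2 thus stands at the limit of > 50000 nM in this assay, at which 2 of the 3 values shown sit; its potency cannot be ordered against compound 1, and compound 3 is the only one of the three for which a number rather than a limit is known.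

Compound 4 `COc1ccc(CN(C(=O)Nc2ccc(C)cc2)n2cnnc2)cc1OC` differs from compound 2 in one place: hydrogen in place of methoxy on an aromatic carbon. Among the measured compounds shown here, no step between two measured compounds covers this change, so any expectation rests on the standing of compound 2 alone, which is a limit and not a number. The step is expected to be none beyond the scatter, at a number no higher from compound 2 to compound 4 (the limit leaves the size open). In this assay compound 4 is therefore estimated at 50000 nM, within a range of 20000 nM to 120000 nM, with a real chance that only a limit is returned again.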

Compound 4, half-maximal inhibitory concentration: > 50000 nM
Compound 4: only a limit was reported; the forecaster's own chance of this, stated with the estimate: 60%; the middle value lies on the limit itself.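

Compound 2 and compound 4 each return only a limit in this assay, so no step can be read from the change of methoxy to hydrogen on the aromatic carbon. The compounds shown leave open whether this change alters potency at all, as neither compound has a number that could be compared in this assay.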